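Swapping a Pyrimidine Sulfide for a Thiadiazole Sulfide

A few compounds are considered here, and "the series" means these few. Any claim that something is new, unique, unknown or untested is made for them only; others in the source may bear on it.

Measured so far:
Compound 1 `COc1ccc(-c2cs/c(=N/NC(=O)CSc3nnc(C)s3)n2-c2ccccc2)cc1` gives 42.6%
Compound 2 `Cc1ccc(-c2cs/c(=N/NC(=O)CSc3ncccn3)n2-c2ccccc2)cc1` gives 82.7%
Compound 3 `COc1ccc(-c2cs/c(=N/NC(=O)CSc3ncccn3)n2-c2ccccc2)cc1` gives 74%

All three were tested in a functional assay on C6 cells (Rattus norvegicus) for cytotoxicity, read by MTT assay, with a stated time of 24 h, tested at 25 ug/mL; a higher number here means a weaker effect of the compound at the concentration tested, a lower number a stronger effect. Compound 2 gives 82.7%, the highest of the three numbers, and compound 3, with 74%, stands within the usual scatter of it. Compound 1, with 42.6%, sits clearly apart.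

Compound 3 and compound 1 differ in one place only: 5-methyl-1,3,4-thiadiazol-2-yl in place of pyrimidin-2-yl on a sulfur. That single exchange brings a number 31.4 percentage points lower from compound 3 to compound 1 (beyond the scatter), a large step and well beyond the scatter. Compound 3 and compound 2 differ elsewhere, in the group on the phenyl ring: methyl in place of methoxy on an aromatic carbon. Here the data give a number 8.7 percentage points lower from compound 2 to compound 3 (within the scatter), which lies within the scatter, so nothing can be said about order between compound 2 and compound 3.

Compound 4 `Cc1ccc(-c2cs/c(=N/NC(=O)CSc3nnc(C)s3)n2-c2ccccc2)cc1` has not yet been measured in this assay. It differs from compound 2 by 5-methyl-1,3,4-thiadiazol-2-yl in place of pyrimidin-2-yl on a sulfur, the same change, at the same place, as that from compound 3 to compound 1; only the core differs, and that difference is the one just described, methyl in place of methoxy. Beside the earlier a number 31.4 percentage points lower from compound 3 to compound 1 (beyond the scatter), the step from compound 2 to compound 4 is expected to be a number 30.7 percentage points lower from compound 2 to compound 4 (beyond the scatter), resting on that single precedent because a number 31.4 percentage points lower from compound 3 to compound 1 (beyond the scatter) is the only measured instance of this change. Compound 4 is therefore expected to give about 52%, most likely between 38% and 68%.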

Compound 4, a percentage reported as activity, at one concentration (the size of the read-out at that concentration, not a potency): 50.1%
For compound 4 the middle estimate is 1.9 percentage points above the measured one; the range from low to high includes it.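

In this assay, placing 5-methyl-1,3,4-thiadiazol-2-yl instead of pyrimidin-2-yl on the sulfur gives a number 32.6 percentage points lower from compound 2 to compound 4 (beyond the scatter), and this step matches the one measured earlier with methoxy in place of methyl on the aromatic carbon: the same change on two cores in this assay, a number 31.4 percentage points lower (beyond the scatter) from compound 3 to compound 1 and a number 32.6 percentage points lower (beyond the scatter) from compound 2 to compound 4, 1.2 percentage points apart, within the scatter of two such steps. The other exchange, methyl in place of methoxy on an aromatic carbon, gives a number 7.5 percentage points higher from compound 1 to compound 4 (within the scatter), and it too reads alike with either group on the sulfur: the same change on two cores in this assay, a number 8.7 percentage points lower (within the scatter) from compound 2 to compound 3 and a number 7.5 percentage points lower (within the scatter) from compound 4 to compound 1, 1.2 percentage points apart, within the scatter of two such steps. So the exchange on the sulfur carried over from one core to the other with its size intact, but this rests on only two pairs whose cores differ by a single small group, and it shows neither why the number falls nor whether the same holds on more distant cores.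

The compounds shown leave open whether another group on the sulfur, such as a 1,3,4-thiadiazol-2-yl without its methyl or a plain phenyl ring, would give a similarly low number, so it remains unknown which part of the new ring matters. They also leave open whether the step would survive with a chlorine atom or a carboxylic acid on the aromatic carbon that carries methyl or methoxy here.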